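Side-chain amine swaps and microsomal clearance in the series

The source may report more compounds than this note shows. Statements on the series, on what has been measured and on what is new or still open speak of the compounds shown alone.

Compound 1 `c1cc([C@H]2CC[C@]3(CC2)OOC2(O3)C3CC4CC(C3)CC2C4)ccc1OCCC1CCNCC1` carries 2-(piperidin-4-yl)ethoxy on an aromatic carbon of the shared core. In an ADME assay on microsomes from liver (Homo sapiens) for metabolic stability, read by LC-MS, tested at 1 uM (a higher number here means faster removal of the compound, a lower number slower removal), compound 1 gives < 7 mL.min-1.g-1, and this is a limit of the assay rather than a number. Compound 2 `O=S(=O)(c1ccc([C@H]2CC[C@]3(CC2)OOC2(O3)C3CC4CC(C3)CC2C4)cc1)N1CCNCC1` gives 16 mL.min-1.g-1 in this assay, and compound 3 `OC1(COc2ccc([C@H]3CC[C@]4(CC3)OOC3(O4)C4CC5CC(C4)CC3C5)cc2)CCNCC1` gives 16 mL.min-1.g-1. Both measured steps away from compound 1 move the same way: an at least 2.2-fold higher number from compound 1 to compound 2 (0.35 log units; beyond the scatter) and an at least 2.2-fold higher number from compound 1 to compound 3 (0.35 log units; beyond the scatter), while no change at the digits printed from compound 2 to compound 3 (within the scatter). Compound 1 thus stands lowest of the three, at the limit of < 7 mL.min-1.g-1 in this assay, at which 1 of the 3 values shown sits.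

Compound 4 `CC(C)(N)CCOc1ccc([C@H]2CC[C@]3(CC2)OOC2(O3)C3CC4CC(C3)CC2C4)cc1` differs from compound 1 only in the amine-bearing chain: 1-amino-1-methylethyl in place of piperidin-4-yl on a saturated chain carbon, two bonds along the chain from an oxygen on an aromatic ring. The piece entering has no ring, whereas each of the other two measured changes on that side of the core also altered the amine-bearing group and each produced a rise beyond the scatter in this assay. That makes a rise the more likely direction for compound 4 as well, though the step from compound 1 starts from a limit, so its true size cannot be fixed. The expected step is an at least 1.5-fold higher number from compound 1 to compound 4 (0.19 log units; that floor lies within the scatter). Compound 4 is therefore estimated at 11 mL.min-1.g-1, with a range from 5 mL.min-1.g-1 to 25 mL.min-1.g-1.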

Compound 4, intrinsic clearance in microsomes: < 7 mL.min-1.g-1
Compound 4 ended at the assay's limit; the forecaster's own chance of this, stated with the estimate: 35%; middle value at least 1.5-fold (0.19 log units) away from the limit.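

Compound 4 gives < 7 mL.min-1.g-1 in this assay, and this is a limit of the assay rather than a number, so a ring in the amine-bearing group is not needed for a reading at that limit on a saturated chain carbon, two bonds along the chain from an oxygen on an aromatic ring. A change of the amine-bearing group therefore need not raise the number: there is an at least 2.2-fold lower number from compound 3 to compound 4 (0.35 log units; beyond the scatter), and there is an at least 2.2-fold lower number from compound 2 to compound 4 (0.35 log units; beyond the scatter). The step between compound 1 and compound 4 cannot be read, and the low end of the series now holds two compounds: the limit of < 7 mL.min-1.g-1 in this assay, at which 2 of the 4 values shown sit.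

On these data alone, with compound 1 and compound 4 both at a limit, their order in this assay stays open, as does whether the hydroxyl of compound 3 or the sulfonyl attachment of compound 2 is what sets those two apart from the low pair. As far as these compounds go, how a morpholine or a carboxylic acid would read at the end of the same chain also remains open.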